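This account rests on a few compounds, and the source may have more. Where it says the series, first, only, none or still open, it means among the compounds named here.

Of the compounds shown here, three that share one core have been tested in a functional assay on A549 cells (Homo sapiens) for cytotoxicity, with a stated time of 48 h; a higher number here means a weaker inhibitor, a lower number a stronger inhibitor: compound 1 `CCOc1ccc2oc(/C=C/[S+](C)[O-])cc(=O)c2c1`, compound 2 `CC(=O)Oc1ccc2oc(/C=C/[S+](C)[O-])cc(=O)c2c1` and compound 3 `C[S+]([O-])/C=C/c1cc(=O)c2cc(Cl)ccc2o1`. They differ in a single group on an aromatic carbon. Compound 1, with ethoxy, gives 1500 nM. Compound 2, with acetoxy, gives 4100 nM. Compound 3, with chloro, gives 1700 nM. Compound 3 therefore lies within the scatter of compound 1, and both have lower numbers than compound 2.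

Compound 4 `CC(C)C(=O)Oc1ccc2oc(/C=C/[S+](C)[O-])cc(=O)c2c1` has not yet been measured. It differs from compound 3 as follows: (isopropylcarbonyl)oxy in place of chloro on an aromatic carbon. In short, (isopropylcarbonyl)oxy takes the place of chloro.

Acetoxy is the closest match among the tested groups to the entering group, and exchanging it for chloro gave a 2.4-fold lower number from compound 2 to compound 3 (0.38 log units; beyond the scatter). Running that exchange in reverse points towards a higher number. Acetyl in place of ethyl gave a step of similar size, a 2.7-fold higher number from compound 1 to compound 2 (0.44 log units; beyond the scatter), while chloro in place of ethoxy gave only a 1.1-fold higher number from compound 1 to compound 3 (0.05 log units; within the scatter). Among the compounds with values here, no tested compound carries the isopropyl part, so its contribution remains unknown. A modest rise of about the size seen with acetoxy is expected, an estimated 2.1-fold higher number from compound 3 to compound 4 (0.33 log units; beyond the scatter). Compound 4 is expected to give about 3600 nM, with an estimated range from 1600 nM to 8000 nM.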

Compound 4, half-maximal inhibitory concentration: 2400 nM
Beside the measured number, compound 4's estimate is 1.5-fold (0.18 log units) above it, and the stated range covers the measured number.
By their numbers in this assay, from the lowest: compounds 1, 3, 4 and 2 (each within the scatter of the next, the first and the last beyond it).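

In this assay, the entering (isopropylcarbonyl)oxy group, with its 6 heavy atoms, cannot be told apart from the single chlorine atom it replaces, as a 1.4-fold higher number from compound 3 to compound 4 (0.15 log units; within the scatter) shows, and it also cannot be told apart from the ethoxy group, as a 1.6-fold higher number from compound 1 to compound 4 (0.20 log units; within the scatter) shows. The comparison with the other ester is new, since isopropyl in place of methyl on the carbonyl carbon gives a 1.7-fold lower number from compound 2 to compound 4 (0.23 log units; within the scatter), so this change has no effect that can be separated from the scatter, and compound 4 stays within reach of every other compound even though compound 2 stands clearly apart from compound 1 and compound 3. No measurement is available that would explain why these numbers fall as they do.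

Going by these compounds, it remains open whether a longer chain or a phenyl ring on the carbonyl carbon would shift the number beyond the scatter, which would show how much room for change this ester has. It is also unknown how an amine, a hydroxyl or a carboxylic acid on the same aromatic carbon would compare with the ester, ethoxy and chloro groups seen so far.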